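Configuration changes from compound 3 to compound 4

The source may hold more compounds than are shown below. What is called first, only, known or untested is meant among the compounds shown, and "the series" means these compounds.

Compound 1 `O=C(O)[C@@H]1NCC=C[C@@H]1O` and compound 2 `O=C(O)[C@@H]1NCC=C[C@H]1O` share atoms and bonds and differ only in the drawn configuration at one saturated ring carbon; in an assay for inhibition of alpha-N-acetylgalactosaminidase (Gallus gallus), tested at 1000 uM (on this read-out lower numbers stand for less inhibition and higher numbers for more inhibition at the one concentration tested (going by the name of the read-out)), compound 1 gives 1.3% and compound 2 gives 3.2%. The step of a number 1.9 percentage points higher from compound 1 to compound 2 (within the scatter) is the only measured one, and it stays within the scatter, which is consistent with the fact that compounds 1 and 2 differ only in the configuration as drawn. Compound 3 `O=C(O)[C@H]1NC[C@@H](O)[C@@H](O)[C@@H]1O` in this assay gives 3.8%, a number that sits with those of compound 1 and compound 2, all within the usual scatter of one another. Compound 4 `O=C(O)[C@@H]1NC[C@@H](O)[C@H](O)[C@@H]1O` is the unmeasured member; it differs from compound 3 as follows: the two compounds have the same atoms and bonds and differ only in configuration as drawn: 2 of 4 stereo elements differ; a stereocentre at a saturated ring carbon is drawn S in compound 3 and R in compound 4; a stereocentre at a saturated ring carbon is drawn R in compound 3 and S in compound 4. Among the compounds with values here, the only step that bears on this change is the one between compound 1 and compound 2, itself a change of configuration alone, and it was within the scatter. A change of configuration at two saturated ring carbons is therefore expected to give no step beyond the scatter in this assay, so that a number 0.2 percentage points higher from compound 3 to compound 4 (within the scatter) is estimated to be small. Compound 4 is accordingly expected to give about 4%, within a range of 0% to 14%.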

Compound 4, a percentage reported as inhibition, at one concentration (the size of the read-out at that concentration, not a potency): 10%
Compound 4: middle estimate off by 6 percentage points, on the low side, within the range that was stated.
By their numbers in this assay, from the lowest: compounds 1, 2, 3 and 4 (each within the scatter of the next).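

In this assay, the reading is a number 6.2 percentage points higher from compound 3 to compound 4 (within the scatter). This extends the picture from the earlier pair, compound 1 and compound 2, where one saturated ring carbon differed: a change of drawn configuration at two saturated ring carbons together also yields no step beyond the scatter. Any reading of this step stays confined to stereochemistry, because of this: the fact that compounds 3 and 4 differ only in the configuration as drawn

The two stereocentres change together in this pair, and the compounds shown do not separate their contributions in this assay. All compounds shown carry the carboxylic acid, and what a methyl ester or a primary amide in its place would give remains open.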